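Replacing the ring-nitrogen benzyl with an aryl carbamoyl

This account rests on a few compounds, and the source may have more. Where it says the series, first, only, none or still open, it means among the compounds named here.

Compound 1 `NC(=O)c1c(NC(=O)c2ccccc2Cl)sc2c1CCN(Cc1ccccc1Cl)C2` is the reference point of this series. In a functional assay on MKN-74 cells (Homo sapiens) for antiproliferative activity, with a stated time of 24 h (a higher number here means a weaker inhibitor, a lower number a stronger inhibitor), compound 1 gives 4430 nM, the lowest of the three numbers recorded, though its neighbours sit within the usual scatter of it. Compound 2 `NC(=O)c1c(NC(=O)c2ccc(C(F)(F)F)cc2)sc2c1CCN(Cc1c(Cl)cccc1Cl)C2` gives 8530 nM in this assay, and compound 3 `NC(=O)c1c(NC(=O)c2ccccc2F)sc2c1CCN(Cc1c(Cl)cccc1Cl)C2` gives 7430 nM. Going by the values given here, the only step between measured compounds that differ in one place, a 1.1-fold lower number from compound 2 to compound 3 (0.06 log units; within the scatter), concerns the group on the carbonyl carbon of the amide and not the substituent on the ring nitrogen, so it offers no direct guide to the change considered here.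

Compound 4 `NC(=O)c1c(NC(=O)c2ccccc2Cl)sc2c1CCN(C(=O)Nc1ccccc1Cl)C2` differs from compound 1 as follows: (2-chlorophenyl)carbamoyl in place of 2-chlorobenzyl on an amine nitrogen in a ring. Among the compounds with values here, no measured pair in this set alters that position, so the expectation rests on the absence of large movements anywhere among the three measured compounds. Compound 4 is therefore expected to remain in the same broad range, with a step of a 1.4-fold higher number from compound 1 to compound 4 (0.13 log units; within the scatter) that is an estimate rather than a prediction from precedent. Compound 4 is estimated at 6000 nM, with a range from 1500 nM to 25000 nM.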

Compound 4, half-maximal inhibitory concentration: 16300 nM
Estimate against measurement, compound 4: 2.7-fold (0.43 log units) below; the range from low to high includes it.
By their numbers in this assay, from the lowest: compounds 1, 3, 2 and 4 (each within the scatter of the next, the first and the last beyond it).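

Going by these compounds alone, the ring-nitrogen substituent is the first place in this set where a single change moves the number beyond the scatter: in this assay, (2-chlorophenyl)carbamoyl in place of 2-chlorobenzyl gives a 3.7-fold higher number from compound 1 to compound 4 (0.57 log units; beyond the scatter). Within the data shown here, the only earlier single-place step, a 1.1-fold lower number from compound 2 to compound 3 (0.06 log units; within the scatter), concerned the group on the carbonyl carbon of the amide and stayed within the scatter, so it gave no sign that the ring nitrogen could shift the number. No supporting data bear on why this swap raises the number.

This single pair cannot separate the contributions of the carbonyl and the amide hydrogen in the entering group. It also leaves open how an acetyl group or a plain methyl on the same ring nitrogen would compare with the 2-chlorobenzyl of compound 1.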